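The compounds below may be only part of what the source reports. "The series", "measured", "known", "first", "only" and "open" are said of these compounds alone.

Within the data shown here, compound 2 `Cc1cc(C(=O)NCN2CCC(c3cccc[n+]3[O-])CC2)ccc1Cl` gives 2460 nM in a functional assay on HEK293 cells for agonist activity at D(4) dopamine receptor (Homo sapiens), read by FLIPR (a higher number here means that more compound is needed for the effect, a lower number that less compound is needed), the highest of the two numbers measured so far; its nearest neighbour is compound 1 `Cc1cc(C)cc(C(=O)NCN2CCC(c3cccc[n+]3[O-])CC2)c1`, which gives 90 nM in this assay. Among the measured compounds shown here, the only step measured in the set is a 27-fold higher number from compound 1 to compound 2 (1.44 log units; beyond the scatter), where 4-chloro-3-methylphenyl replaced 3,5-dimethylphenyl on the carbonyl carbon. Compound 3 `O=C(NCN1CCC(c2cccc[n+]2[O-])CC1)c1cc(Cl)cc(Cl)c1` has not been measured; it differs from compound 2 by 3,5-dichlorophenyl in place of 4-chloro-3-methylphenyl on a carbonyl carbon. This change restores the 3,5-substitution pattern of compound 1 while keeping chlorine in place of methyl, so the large step seen between compound 1 and compound 2 bears on it in reverse, though only in part. Compound 3 is therefore expected to lie between the two measured compounds, with the step from compound 2 estimated as a 7.0-fold lower number from compound 2 to compound 3 (0.85 log units; beyond the scatter). The estimate for compound 3 in this assay is 350 nM, within a range of 90 nM to 1400 nM.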

Compound 3, half-maximal effective concentration: 45 nM
Compound 3: middle estimate off by 7.8-fold (0.89 log units), on the high side, outside the stated range (below it).
By their numbers in this assay, from the lowest: compounds 3 and 1 (each within the scatter of the next); then compound 2.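

The new result separates two things that compound 1 and compound 2 alone could not: chlorine on the ring and the 4-chloro-3-methylphenyl pattern. In this assay there is a 55-fold lower number from compound 2 to compound 3 (1.74 log units; beyond the scatter), while a 2.0-fold lower number from compound 1 to compound 3 (0.30 log units; within the scatter), so 3,5-dichlorophenyl and 3,5-dimethylphenyl cannot be told apart here, and across these three compounds the high number goes with 4-chloro-3-methylphenyl and not with chlorine as such. No measurement is at hand that explains this difference.

From the compounds shown here alone, whether methoxy or trifluoromethyl groups in place of the two chlorines of 3,5-dichlorophenyl would give a number like that of compound 3 remains open, as does the result for a plain phenyl ring. The three compounds also share the rest of their structure, so they say nothing about whether the pattern holds on a different amine or a longer chain at the amide nitrogen.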